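From 4-hydroxybenzyl to 2,5-dihydroxybenzyl in cytotoxicity

The source may hold more compounds than are shown below. What is called first, only, known or untested is meant among the compounds shown, and "the series" means these compounds.

In a functional assay on P388 cells (Mus musculus) for cytotoxicity (a higher number here means a weaker inhibitor, a lower number a stronger inhibitor), the compounds measured so far are these:

Compound 1 `Cc1cc(-c2c(F)cc3c(=O)c(Cc4ccccc4O)cn(C4CC4)c3c2F)cc(C)n1` gives 670 nM
Compound 2 `Cc1cc(-c2c(F)cc3c(=O)c(Cc4ncc[nH]4)cn(C4CC4)c3c2F)cc(C)n1` gives 1100 nM
Compound 3 `Cc1cc(-c2c(F)cc3c(=O)c(Cc4ccc(O)cc4)cn(C4CC4)c3c2F)cc(C)n1` gives 1500 nM

Compound 3 cannot be separated from its nearest neighbour (a 1.4-fold higher number from compound 2 to compound 3 (0.13 log units; within the scatter)) but stands clear of the furthest one (a 2.2-fold higher number from compound 1 to compound 3 (0.35 log units; beyond the scatter)). Compound 4 `Cc1cc(-c2c(F)cc3c(=O)c(Cc4cc(O)ccc4O)cn(C4CC4)c3c2F)cc(C)n1` has yet to be measured and differs from compound 3 in one place (2,5-dihydroxyphenyl in place of 4-hydroxyphenyl on a saturated chain carbon bound to an aromatic carbon). The entering 2,5-dihydroxyphenyl group contains the 2-hydroxyphenyl pattern of compound 1 (670 nM), so the step between the two hydroxyphenyl compounds is the closest guide, and it is modest. The step to the imidazole (a 1.6-fold higher number from compound 1 to compound 2 (0.22 log units; within the scatter)) lies within the scatter and adds little. Within the data shown here, no measured compound carries the 2,5-dihydroxyphenyl group, so this guide is a weak one. In this assay a modest move towards a lower number is therefore expected (a 2.1-fold lower number from compound 3 to compound 4 (0.33 log units; beyond the scatter)). The estimate for compound 4 is 700 nM (expected range 250 nM to 1800 nM).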

Compound 4, half-maximal inhibitory concentration: 360 nM
Compound 4: the middle estimate sits 1.9-fold (0.29 log units) above what was measured; measured number inside the range.
By their numbers in this assay, from the lowest: compounds 4, 1, 2 and 3 (each within the scatter of the next, the first and the last beyond it).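

In this assay, the 2,5-dihydroxyphenyl group is the only group shown on this saturated chain carbon that stands clear of both the 4-hydroxyphenyl group (a 4.2-fold lower number from compound 3 to compound 4 (0.62 log units; beyond the scatter)) and the 1H-imidazol-2-yl group (a 3.1-fold lower number from compound 2 to compound 4 (0.49 log units; beyond the scatter)), whereas the 2-hydroxyphenyl group of compound 1 stands clear of the former alone. Hydroxy in place of hydrogen on an aromatic carbon, however, gives no separable change (a 1.9-fold lower number from compound 1 to compound 4 (0.27 log units; within the scatter)), so the step from compound 3 is not shown to need more than the 2-hydroxyphenyl pattern already present in compound 1. Nothing available accounts for these steps. From the compounds shown here alone, whether methoxy or amino groups could stand in for either hydroxy remains open. So does whether a longer chain at this place would keep the same level.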